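Propargyl ester swap on the aminophenyl chromene series

The compounds below may be only part of what the source reports. "The series", "measured", "known", "first", "only" and "open" are said of these compounds alone.

Compound 1 `CCOC(=O)CC1C(C(=O)OCC)=C(N)Oc2ccc(-c3ccc(N)cc3)cc21` gives 22300 nM in a functional assay on HL-60 cells (Homo sapiens) for cytotoxicity, read by CellTiter-Blue, with a stated time of 48 h; a higher number here means a weaker inhibitor, a lower number a stronger inhibitor. Compound 2 `C#CCOC(=O)CC1C(C(=O)OCC)=C(N)Oc2ccc(-c3ccc(N)cc3)cc21` gives 10500 nM in this assay, and compound 3 `CCOC(=O)CC1C(C(=O)OCC)=C(N)Oc2ccc(-c3cccc(NC)c3)cc21` gives 7450 nM. Compound 3 holds the lowest number of the three; its gap to compound 2 lies within the scatter, its gap to compound 1 beyond it. The step of a 2.1-fold lower number from compound 1 to compound 2 (0.33 log units; beyond the scatter) accompanies the change (ethynyl in place of methyl on a saturated chain carbon bound to an oxygen next to a carbonyl group). The step of a 3.0-fold lower number from compound 1 to compound 3 (0.48 log units; beyond the scatter) accompanies the core change (3-(methylamino)phenyl in place of 4-aminophenyl on an aromatic carbon). Compound 4 `C#CCOC(=O)CC1C(C(=O)OCC)=C(N)Oc2ccc(-c3cccc(NC)c3)cc21` carries the same change as compound 2, (ethynyl in place of methyl on a saturated chain carbon bound to an oxygen next to a carbonyl group), on the core of compound 3, at the same place. For compound 4 the expected step is a 2.1-fold lower number from compound 3 to compound 4 (0.32 log units; beyond the scatter), because the same change once gave a 2.1-fold lower number from compound 1 to compound 2 (0.33 log units; beyond the scatter); with a single precedent the expectation is loose. Compound 4 is estimated at 3600 nM in this assay, between 1800 nM and 7500 nM.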

Compound 4, half-maximal inhibitory concentration: 7130 nM
Compound 4: middle estimate off by 2.0-fold (0.30 log units), on the low side; low and high end bracket the measured number.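

The ethyl to propargyl change gives a 1.0-fold lower number from compound 3 to compound 4 (0.02 log units; within the scatter) on the second core, and this step cannot be told apart from the earlier one: the same change on two cores in this assay, a 2.1-fold lower number (0.33 log units; beyond the scatter) from compound 1 to compound 2 and a 1.0-fold lower number (0.02 log units; within the scatter) from compound 3 to compound 4, 2.0-fold (0.31 log units) apart, within the scatter of two such steps. The change from 4-aminophenyl to 3-(methylamino)phenyl, read on the propargyl esters, gives a 1.5-fold lower number from compound 2 to compound 4 (0.17 log units; within the scatter), and it too stays unseparated from its earlier step: the same change on two cores in this assay, a 3.0-fold lower number (0.48 log units; beyond the scatter) from compound 1 to compound 3 and a 1.5-fold lower number (0.17 log units; within the scatter) from compound 2 to compound 4, 2.0-fold (0.31 log units) apart, within the scatter of two such steps. The two cores therefore give no firm sign that either change depends on its partner, yet a single pair of steps in this assay cannot show that either carries over at a fixed size.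

Open, on these data alone, is how a longer chain ester or a free carboxylic acid would read at the ester position. Also open, as far as these compounds go, is how a dimethylamino group would read on the phenyl ring.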